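This account rests on a few compounds, and the source may have more. Where it says the series, first, only, none or still open, it means among the compounds named here.

Compound 1 `CCC1=C(O)c2c(oc(-c3ccc(OC(F)(F)F)cc3)cc2=O)C(CC)(CC)C1=O` and compound 2 `CCC1=C(O)c2c(oc(-c3ccc(F)cc3)cc2=O)C(CC)(CC)C1=O` share one core and differ only in the group on the aromatic ring. In a functional assay on KB cells (Homo sapiens) for antiproliferative activity, read by sulforhodamine B assay, with a stated time of 3 days (a lower number here means that less compound is needed, a higher number that more compound is needed for the effect), compound 1 gives 36.5 uM. In this assay compound 2 gives 33 uM. The change fluoro in place of trifluoromethoxy on an aromatic carbon therefore gives a 1.1-fold lower number from compound 1 to compound 2 (0.04 log units; within the scatter).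

Compound 3 `CCC1=C(O)c2c(oc(-c3cccc(OC(F)(F)F)c3)cc2=O)C(CC)(CC)C1=O` has the same atoms as compound 1, joined differently; the difference between the two cores is not broken down here. In this assay compound 3 gives only a limit of the assay, > 47.4 uM, not a number.

Compound 4 `CCC1=C(O)c2c(oc(-c3cccc(F)c3)cc2=O)C(CC)(CC)C1=O` is not yet measured in this assay. It differs from compound 3 by fluoro in place of trifluoromethoxy on an aromatic carbon, the same kind of change as that from compound 1 to compound 2, though the place is not identical: para to a large group in the earlier pair, meta to a large group here. Since compound 3 sits at the limit of > 47.4 uM in this assay, at which 1 of the 3 values shown sits, the step to compound 4 is expected to be an at least 1.0-fold lower number from compound 3 to compound 4 (0.02 log units; that floor lies within the scatter), resting on the earlier step having been within the scatter. Compound 4 is thus expected near 45 uM, with a likely range from 25 uM to 100 uM, and a real chance that again only a limit is reported.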

Compound 4, concentration for half-maximal effect: > 56.2 uM
Compound 4 ended at the assay's limit; the forecaster's own chance of this, stated with the estimate: 50%; at least 1.2-fold (0.09 log units) between middle value and limit.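

In this assay, the change from trifluoromethoxy to fluoro was flat on the core of compound 1, with a 1.1-fold lower number from compound 1 to compound 2 (0.04 log units; within the scatter), but that result cannot be tested on the core of compound 3. Compound 4 gives > 56.2 uM, a limit of the assay and not a number, and with compound 3 also at a limit, the step between them cannot be read, so the notes neither confirm nor refute that the change carries over. Among the compounds shown here, the only readable comparison concerns 3-fluorophenyl in place of 4-fluorophenyl, with an at least 1.7-fold higher number from compound 2 to compound 4 (0.23 log units; that floor lies within the scatter), so this floor does not by itself separate the two compounds.

Still open, from the compounds shown here alone, is whether the change from trifluoromethoxy to fluoro has any measurable size on the core of compound 3, which would need values that are numbers rather than limits. Also open, going by these compounds, is whether an amine or a carboxylic acid on the same aromatic carbon would give a number in this assay.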